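The source may hold more compounds than are shown below. What is called first, only, known or untested is meant among the compounds shown, and "the series" means these compounds.

Values measured in an ADME assay on Vero cells (Chlorocebus sabaeus) for cytotoxicity, read by MTT assay, with a stated time of 96 h; a higher number here means that more compound is tolerated, a lower number that less compound is tolerated:
- compound 1 `COc1ccc(-c2nc3cc(C(C)O)ccc3[nH]2)cc1`: > 100000 nM
- compound 2 `COc1ccc(-c2nc3cc(C(C)O)ccc3[nH]2)c(OC)c1`: > 100000 nM

Compound 2 stands at > 100000 nM, which is a limit of the assay and not a number. Compound 1 also gives only a limit, > 100000 nM. The picture so far is therefore (the limit of > 100000 nM in this assay, at which 2 of the 2 values shown sit). Going by the values given here, the one measured step is a step that the two limits leave unreadable from compound 1 to compound 2, so it offers no size to carry forward, and it concerns a different change in any case.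

Compound 3 `COc1ccc(-c2nc3cc(/C(C)=N/NC(N)=S)ccc3[nH]2)c(OC)c1` keeps the core of compound 2 but replaces the 1-hydroxyethyl group on an aromatic carbon: a group of 7 heavy atoms (3 carbon, 3 nitrogen, 1 sulfur; no ring) in place of a group of 3 heavy atoms (2 carbon, 1 oxygen; no ring), on an aromatic carbon. Among the compounds with values here, no measured step touches this place, so the forecast rests on the structural change alone and stays uncertain. The expectation is a move towards less compound being tolerated, although the result may well stay at the limit of this assay. The expected step is an at least 2.5-fold lower number from compound 2 to compound 3 (0.39 log units; beyond the scatter). For compound 3 the estimated value is 40000 nM, with an expected range from 8000 nM to 100000 nM.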

Compound 3, half-maximal cytotoxic concentration: > 100000 nM
Compound 3 was reported as a limit (the forecaster's own chance of this, stated with the estimate: 35%); middle value at least 2.5-fold (0.39 log units) from the limit.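

In this assay compound 3 gives > 100000 nM, a limit of the assay and not a number. Going by these compounds alone, compound 2 also gives only a limit, so no step between compound 2 and compound 3 can be read. The compounds shown leave open how much of each is actually tolerated, and whether replacing the 1-hydroxyethyl group changes that, because all share one result: the limit of > 100000 nM in this assay, at which 3 of the 3 values shown sit.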